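The source may hold more compounds than are shown below. What is called first, only, known or untested is meant among the compounds shown, and "the series" means these compounds.

Compound 1 `O=C(Nc1ccc(Oc2ccnc3[nH]ccc23)cc1)c1ccc(-c2ccc(F)cc2F)cn1` gives > 10000 nM in a functional assay on MCF7 cells (Homo sapiens) for cytotoxicity, read by MTT assay, with a stated time of 72 h (a higher number here means a weaker inhibitor, a lower number a stronger inhibitor), which is a limit of the assay rather than a number.
Compound 2 `O=C(Nc1ccc(Oc2ccnc3[nH]ccc23)cc1)c1cc(-c2ccccc2)ccn1` gives 3750 nM in this assay.
Compound 3 `O=C(Nc1ccc(Oc2ccnc3[nH]ccc23)c(F)c1)c1cc(-c2ccccc2)ccn1` gives > 10000 nM in this assay, again a limit of the assay rather than a number.

Compound 3 therefore stands at the limit of this assay, where two of the three values sit (the limit of > 10000 nM in this assay, at which 2 of the 3 values shown sit). Among the measured compounds shown here, the only step measured so far, an at least 2.6-fold higher number from compound 2 to compound 3 (0.42 log units; beyond the scatter), moved the number from a measured value onto that limit, so the true position of compound 3 is known only as a floor.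

Compound 4 `O=C(Nc1ccc(Oc2ccnc3[nH]ccc23)c(F)c1)c1cc(-c2ccc(C(F)(F)F)cc2)ccn1` differs from compound 3 in one place: trifluoromethyl in place of hydrogen on an aromatic carbon. For the measured compounds named here, no measured step involves a trifluoromethyl, so nothing among the three compounds speaks directly to the size or direction of this change. Compound 1 also sits at the limit, but it is not a single-step neighbour of any other compound.

The expectation for compound 4 in this assay rests mainly on the fact that compound 3 already gives > 10000 nM, so compound 4 is expected to sit at or beyond the same limit, with a step that the limit leaves unreadable from compound 3 to compound 4 as the estimated step. The estimate for compound 4 is 15000 nM, within a range from 5000 nM to 50000 nM.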

Compound 4, half-maximal inhibitory concentration: 8550 nM
Estimate against measurement, compound 4: 1.8-fold (0.24 log units) above; measured number inside the range.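

Phenyl to 4-(trifluoromethyl)phenyl gives, in this assay, an at least 1.1-fold lower number from compound 3 to compound 4 (0.06 log units; that floor lies within the scatter), the first step here that starts from a limit and ends on a measured number. The printed size is only a floor and lies within the scatter, so the result does not establish a real gain, but it does show that a trifluoromethyl at this place, para to a large group, can leave the value on the measurable side of the limit, and it gives the fluoro-bearing compounds a first measured reference for later comparisons. The real size of the step cannot be read because its starting point, compound 3, sits at a limit: the limit of > 10000 nM in this assay, at which 2 of the 4 values shown sit.

The compounds shown leave open whether the same place would respond alike to an amine, a carboxylic acid or a methoxy group, since trifluoromethyl is the only group shown there. They also leave open how 4-(trifluoromethyl)phenyl would read on the core of compound 2, without the ring fluoro, which would show whether the trifluoromethyl step depends on that fluoro.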